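Second acetoxy on compound 1

A few compounds are considered here, and "the series" means these few. Any claim that something is new, unique, unknown or untested is made for them only; others in the source may bear on it.

For the measured compounds named here, compound 1 `CC(=O)Oc1cccc(/C=C/C(=O)Nc2ccc3c(c2)COC3=O)c1` holds the lowest number so far in a functional assay on cells (T-cell, Mus musculus) for inhibition (a lower number here means a stronger inhibitor, a higher number a weaker inhibitor), at 30 nM. Going by the values given here, compound 2 `CC(C)(C)c1ccc(/C=C/C(=O)Nc2ccc3c(c2)COC3=O)cc1`, the only other measured compound, gives 720 nM, a gap beyond the scatter. Among the compounds with values here, no measured pair differs in one place only, so the series offers no direct step to scale from.

Compound 3 `CC(=O)Oc1ccc(/C=C/C(=O)Nc2ccc3c(c2)COC3=O)cc1OC(C)=O` keeps the core of compound 1 and carries one change: acetoxy in place of hydrogen on an aromatic carbon, ortho to an acetoxy group and para to a large group. Compound 1 already carries an acetoxy group at 30 nM, so no large step is expected in this assay. The estimated step of a 1.5-fold higher number from compound 1 to compound 3 (0.18 log units; within the scatter) is a slight rise in the number, within the scatter. Compound 3 is expected at 45 nM, with an estimated range of 10 nM to 200 nM.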

Compound 3, half-maximal inhibitory concentration: 180 nM
For compound 3 the middle estimate is 4.0-fold (0.60 log units) below the measured one; measured number inside the range.
By their numbers in this assay, from the lowest: compound 1; then compound 3; then compound 2.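

In this assay, for the compounds shown here, acetoxy in place of hydrogen on an aromatic carbon, ortho to an acetoxy group and para to a large group, gives a 6.0-fold higher number from compound 1 to compound 3 (0.78 log units; beyond the scatter) as the first step that differs in one place. A second acetoxy group at this position therefore does not keep the number of compound 1, and one acetoxy group on the core does not predict what a second will do. No measurement shown accounts for the rise.

From the compounds shown here alone, whether the rise is specific to acetoxy at this position remains open, and a hydroxy group, a methoxy group or a fluorine atom on the same aromatic carbon would separate that question from the change in general. Going by these compounds alone, also open is how the single acetoxy group of compound 1 itself contributes, which a hydroxy group or an amine in its place would address.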